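Removing the Extension from Compound 2

This account rests on a few compounds, and the source may have more. Where it says the series, first, only, none or still open, it means among the compounds named here.

Compound 1 `COc1cc(NC(C)CCCNC(=O)Nc2cccc(F)c2)c2ncccc2c1`: 21000 nM
Compound 2 `COc1cc(NC(C)CCCNC(=O)NNC(=O)Nc2ccc(O)cc2)c2ncccc2c1`: 111000 nM

In a functional assay on CCRF-CEM cells (Homo sapiens) for inhibition, read by MTT assay, with a stated time of 72 h (a higher number here means a weaker inhibitor, a lower number a stronger inhibitor), compound 2 has the higher number of the pair, 111000 nM. Compound 3 `COc1cc(NC(C)CCCNC(=O)Nc2ccc(O)cc2)c2ncccc2c1` differs from it by 4-hydroxyphenyl in place of ((4-hydroxyphenyl)carbamoyl)amino on an amide-type nitrogen. Within the data shown here, the one measured step that bears on this, a 5.3-fold higher number from compound 1 to compound 2 (0.72 log units; beyond the scatter), brought that same group in place of 3-fluorophenyl. Removing it should therefore give a step of similar size toward a lower number, although 4-hydroxyphenyl is not 3-fluorophenyl. The expected change is a 3.7-fold lower number from compound 2 to compound 3 (0.57 log units; beyond the scatter). For compound 3 the estimate is 30000 nM, with an expected range of 10000 nM to 90000 nM.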

Compound 3, half-maximal inhibitory concentration: 23000 nM
Compound 3: middle estimate off by 1.3-fold (0.12 log units), on the high side; measured number inside the range.
By their numbers in this assay, from the lowest: compounds 1 and 3 (each within the scatter of the next); then compound 2.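

Removing the ((4-hydroxyphenyl)carbamoyl)amino extension from the amide-type nitrogen gives a 4.8-fold lower number from compound 2 to compound 3 (0.68 log units; beyond the scatter) in this assay and shows that the higher number of compound 2 goes with the extension, since 4-hydroxyphenyl alone does not carry it. Exchanging 3-fluorophenyl for 4-hydroxyphenyl gives a 1.1-fold higher number from compound 1 to compound 3 (0.04 log units; within the scatter) and so leaves these two groups indistinguishable at this position. Nothing available explains either result. Open, from the compounds shown here alone, is how a group of another kind on this nitrogen, such as a carboxylic acid or a simple amine, would compare with 3-fluorophenyl and 4-hydroxyphenyl.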